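Tolerance of an Alkyl Chain Change on Lung Cells

The source may hold more compounds than are shown below. What is called first, only, known or untested is meant among the compounds shown, and "the series" means these compounds.

Compound 1 `O=C(Nc1ccc(N2CCCC2)cc1Cl)c1cc(Cl)ccc1O`: "not determined" (no result reported).
Compound 2 `O=C(Nc1ccc(NCCCO)cc1Cl)c1cc(Cl)ccc1O`: "not determined" (no result reported).
Compound 3 `O=C(Nc1ccc(NCC2CCCC2)cc1Cl)c1cc(Cl)ccc1O`: 141000 nM.

Three compounds share one core and differ only in the group on the aromatic nitrogen. In an ADME assay on A549 cells (Homo sapiens) for cytotoxicity, read by LDH release, with a stated time of 15 h (a lower number here means that less compound is tolerated, a higher number that more compound is tolerated), compound 1 gives "not determined" (no result reported) and compound 2 gives "not determined" (no result reported), so nothing can be said of how they compare. In this assay, going by the values given here, compound 3 gives 141000 nM, and that is the only number on hand; compound 3 stands alone rather than at any rank among measured compounds.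

Compound 4 `CCCCCCC(C)Nc1ccc(NC(=O)c2cc(Cl)ccc2O)c(Cl)c1` is not yet measured. It differs from compound 3 in one place: 1-methylheptyl in place of cyclopentylmethyl on a nitrogen on an aromatic ring. Among the compounds with values here, no step between two measured compounds is available to calibrate what such an exchange does in this assay, and a single value gives no trend to lean on.

With only compound 3 as anchor, the expectation for compound 4 is a step about the size of the usual scatter, leaning towards a lower number, a 1.4-fold lower number from compound 3 to compound 4 (0.15 log units; within the scatter). On that basis compound 4 is estimated at 100000 nM in this assay, with a range from 40000 nM to 250000 nM.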

Compound 4, half-maximal cytotoxic concentration: 18600 nM
For compound 4 the middle estimate is 5.4-fold (0.73 log units) above the measured one; the whole stated range lies above it.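

Going by these compounds alone, replacing cyclopentylmethyl with 1-methylheptyl on a nitrogen on an aromatic ring gives the first step that can be read at this position. In this assay there is a 7.6-fold lower number from compound 3 to compound 4 (0.88 log units; beyond the scatter) and this lies beyond the scatter, so the number in this cell assay does respond to the group on this nitrogen. The exchange removes a five-membered ring of carbon only and goes from 6 to 8 heavy atoms, so the loss of the ring and the gain in size arrive together in this one pair, and nothing on hand accounts for the change in the number.

Whether the step follows the opening of the ring, the branching methyl or the added carbon cannot be separated with these compounds alone. Also open, as far as these compounds go, is how the number would read with a straight heptyl chain, a cyclohexylmethyl group, or a chain ending in an amine or a carboxylic acid on the same nitrogen, so two compounds give one step and no trend along the series.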